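The compounds below may be only part of what the source reports. "The series", "measured", "known", "first", "only" and "open" are said of these compounds alone.

Within the data shown here, in a functional assay on A549 cells (Homo sapiens) for antiproliferative activity, read by CCK-8 assay, with a stated time of 72 h (a higher number here means a weaker inhibitor, a lower number a stronger inhibitor), compound 1 `CCc1ccc(C(=O)Nc2cccc(-c3oc4cc(-c5ccc(F)cc5)ccc4c(=O)c3O)c2)cc1` gives 18500 nM and compound 2 `Cc1cc(C)cc(C(=O)Nc2cccc(-c3oc4cc(-c5ccc(F)cc5)ccc4c(=O)c3O)c2)c1` gives 3740 nM; compound 2 stands lowest of the two numbers, and the only measured step is a 4.9-fold lower number from compound 1 to compound 2 (0.69 log units; beyond the scatter). Compound 3 `O=C(Nc1cccc(-c2oc3cc(-c4ccc(F)cc4)ccc3c(=O)c2O)c1)c1cnc(Cl)nc1Cl` carries 2,4-dichloropyrimidin-5-yl in place of 3,5-dimethylphenyl on a carbonyl carbon. That one measured step also swapped the aryl group on the carbonyl carbon, so it bears loosely here, but nothing in the series covers a heteroaryl with two chlorines. Measured against compound 2, the number for compound 3 is expected to shift by the estimated step of a 1.6-fold higher number from compound 2 to compound 3 (0.21 log units; within the scatter), a change not clearly beyond the scatter. The estimate for compound 3 is 6000 nM, ranging from 1500 nM to 25000 nM.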

Compound 3, half-maximal inhibitory concentration: > 100000 nM
Compound 3: only a limit was reported; the forecaster's own chance of this, stated with the estimate: 5%; middle value at least 16-fold (1.22 log units) from the limit.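

In this assay compound 3 gives only a limit, not a number: the limit of > 100000 nM in this assay, at which 1 of the 3 values shown sits.

Changing the aryl group on the carbonyl carbon can therefore cost far more than the earlier pair suggested, with 2,4-dichloropyrimidin-5-yl giving an at least 26-fold higher number from compound 2 to compound 3 (1.42 log units; beyond the scatter) and an at least 5.4-fold higher number from compound 1 to compound 3 (0.73 log units; beyond the scatter). 3,5-Dimethylphenyl and 2,4-dichloropyrimidin-5-yl match in heavy-atom count, so that count alone does not decide the outcome.

As far as these compounds go, whether the drop follows the ring nitrogens or the chlorines remains open. An unsubstituted pyrimidin-5-yl and a 2,4-dichlorophenyl on the same carbonyl carbon would separate the two.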